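The source may report more compounds than this note shows. Statements on the series, on what has been measured and on what is new or still open speak of the compounds shown alone.

Of the compounds shown here, three sharing one core have been tested in a functional assay on A549 cells (Homo sapiens) for antiproliferative activity, read by MTT assay, with a stated time of 24 h; on this read-out lower numbers stand for stronger inhibition and higher numbers for weaker inhibition. Compound 1 `COc1ccc(-c2cc(C(=O)/C=C/c3ccccc3)nc3cc(-c4ccccc4)nn23)cc1OC` gives 18600 nM. Compound 2 `COc1ccc(-c2cc(/C=C/C(=O)c3ccc(C)c(C)c3)nc3cc(-c4ccccc4)nn23)cc1OC` gives 9300 nM. Compound 3 `COc1ccc(C(=O)/C=C/c2cc(-c3ccc(OC)c(OC)c3)n3nc(-c4ccccc4)cc3n2)cc1OC` gives 3900 nM, the lowest number of the three. Between them came a 2.0-fold lower number from compound 1 to compound 2 (0.30 log units; within the scatter) and then a 2.4-fold lower number from compound 2 to compound 3 (0.38 log units; beyond the scatter). Compound 4 `COc1ccc(-c2cc(/C=C/C(=O)c3ccc(Cl)cc3)nc3cc(-c4ccccc4)nn23)cc1OC` has not yet been measured. It differs from compound 3 by 4-chlorophenyl in place of 3,4-dimethoxyphenyl on a carbonyl carbon. Within the data shown here, the only measured step that bears on this change is a 2.4-fold lower number from compound 2 to compound 3 (0.38 log units; beyond the scatter), in which 3,4-dimethoxyphenyl on the carbonyl carbon went with a modestly lower number. Among the measured compounds shown here, removing that group for 4-chlorophenyl, which no measured compound carries, is therefore expected to give a modest rise, a 1.9-fold higher number from compound 3 to compound 4 (0.28 log units; within the scatter). In this assay compound 4 is estimated at 7500 nM, with a range from 2500 nM to 22000 nM.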

Compound 4, half-maximal inhibitory concentration: 15400 nM
The estimate for compound 4 lay 2.1-fold (0.31 log units) below the measured number; measured number inside the range.
By their numbers in this assay, from the lowest: compound 3; then compounds 2, 4 and 1 (each within the scatter of the next).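

Swapping the group on this carbonyl carbon does matter: 4-chlorophenyl in place of 3,4-dimethoxyphenyl gives a 3.9-fold higher number from compound 3 to compound 4 (0.60 log units; beyond the scatter), whereas in place of 3,4-dimethylphenyl it gives only a 1.7-fold higher number from compound 2 to compound 4 (0.22 log units; within the scatter), so among these three groups 3,4-dimethoxyphenyl alone stands apart. Replacing (2-phenylethenyl)carbonyl with 2-((4-chlorophenyl)carbonyl)ethenyl on the aromatic carbon gives a 1.2-fold lower number from compound 1 to compound 4 (0.08 log units; within the scatter), so that larger change shows no separable effect. No measurement here explains why the 3,4-dimethoxyphenyl group stands apart. On these data alone, how a phenyl ring carrying an amine or a carboxylic acid would behave on this carbonyl carbon remains open.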